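Shortening the side chain on compound 3

A few compounds are considered here, and "the series" means these few. Any claim that something is new, unique, unknown or untested is made for them only; others in the source may bear on it.

Measured so far:
Compound 1, `CN1CCN(c2nc3ccccc3n2CCOCCO)CC1`, gives 42 nM in a functional assay on ileum for inhibition of histamine H1 receptor (Cavia porcellus); a higher number here means a weaker inhibitor, a lower number a stronger inhibitor.
Compound 2, `CN1CCN(c2nc3ccccc3n2-c2ccccc2)CC1`, gives 760 nM in this assay.
Compound 3, `CCCC(C)Cn1c(N2CCN(C)CC2)nc2ccccc21`, gives 500 nM in this assay.

Compound 3 stands second highest of the three numbers: close to compound 2, as a 1.5-fold lower number from compound 2 to compound 3 (0.18 log units; within the scatter) shows, and far from compound 1, as a 12-fold higher number from compound 1 to compound 3 (1.08 log units; beyond the scatter) shows. Compound 4, `CCCn1c(N2CCN(C)CC2)nc2ccccc21`, differs from compound 3 by hydrogen in place of propyl on a saturated chain carbon bound to two saturated chain carbons. Among the measured compounds shown here, two measured steps touch this position: a 12-fold higher number from compound 1 to compound 3 (1.08 log units; beyond the scatter), which was large, and a 1.5-fold lower number from compound 2 to compound 3 (0.18 log units; within the scatter), which was not. For the measured compounds named here, neither step shortens a plain alkyl chain, and no measured compound carries an alkyl group smaller than 2-methylpentyl there. Without such a precedent, only a modest step is expected. Compound 4 is expected to give 350 nM, within 120 nM to 1000 nM, a step of a 1.4-fold lower number from compound 3 to compound 4 (0.15 log units; within the scatter) that is expected to stay close to the scatter.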

Compound 4, half-maximal inhibitory concentration: 380 nM
Beside the measured number, compound 4's estimate is 1.1-fold (0.04 log units) below it; low and high end bracket the measured number.
By their numbers in this assay, from the lowest: compound 1; then compounds 4, 3 and 2 (each within the scatter of the next).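

Going from 2-methylpentyl to propyl on the aromatic nitrogen gives a 1.3-fold lower number from compound 3 to compound 4 (0.12 log units; within the scatter) in this assay, so the first plain alkyl shortening shows no change that can be told from the scatter. With propyl in place, a 2.0-fold lower number from compound 2 to compound 4 (0.30 log units; within the scatter) also stays within the scatter, while a 9.0-fold higher number from compound 1 to compound 4 (0.96 log units; beyond the scatter) leaves compound 1 as the only one of the four set apart by its 2-(2-hydroxyethoxy)ethyl chain. No supporting evidence explains that gap.

Still open, on these data alone, is which part of that chain matters, the ether oxygen or the end hydroxyl. Also open, as far as these compounds go, is how a methyl group, or a chain ending in an amine or a carboxylic acid, would read here.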